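The source may hold more compounds than are shown below. What is called first, only, known or untested is meant among the compounds shown, and "the series" means these compounds.

Among the compounds with values here, in a functional assay on NCI-H226 cells (Homo sapiens) for inhibition (a higher number here means a weaker inhibitor of growth, a lower number a stronger inhibitor of growth), compound 1 `COc1ccc(-n2cnnc2-c2cc(OC)c(OC)c(OC)c2)cc1` gives 5250 nM, the lower of the two numbers measured so far and so the stronger inhibitor of the pair. Compound 2 `COc1cc(-c2nncn2-c2ccc(N(C)C)cc2)cc(OC)c1OC` gives 100000 nM. The next compound, compound 3 `COc1ccc(-n2cnnc2-c2cc(OC)c(OC)c(OC)c2)cc1O`, keeps all of compound 1 and adds one group: hydroxy in place of hydrogen on an aromatic carbon. In words, this is hydroxy in place of hydrogen on an aromatic carbon, ortho to a methoxy group.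

Within the data shown here, only one measured step bears on this change, and it is an imperfect guide. Dimethylamino in place of methoxy gave a 19-fold higher number from compound 1 to compound 2 (1.28 log units; beyond the scatter), a large step beyond the scatter. That step shows that a single change on an aromatic carbon can move this read-out a long way, but it replaces a group instead of adding a hydroxy, so it does not settle the direction here. The direction below is a judgement, and the range is kept wide to match. The expected change is a 13-fold lower number from compound 1 to compound 3 (1.12 log units; beyond the scatter), towards stronger inhibition. For compound 3 the estimated value is 400 nM, with an expected range from 25 nM to 5000 nM.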

Compound 3, concentration for 50% growth inhibition: < 100000 nM
Compound 3 was reported as a limit; the forecaster's own chance of this, stated with the estimate: 3%; the middle value lies beyond the limit too.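

In this assay compound 3 gives < 100000 nM, which is a limit and not a number. The step from compound 1 to compound 3 therefore cannot be read. The compounds shown leave open whether hydroxy in place of hydrogen on an aromatic carbon, ortho to a methoxy group, changes growth inhibition at all, and if so in which direction and how far.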